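A few compounds are considered here, and "the series" means these few. Any claim that something is new, unique, unknown or untested is made for them only; others in the source may bear on it.

Compound 1 `O=C(Nc1cccc(NC(=O)c2ccccn2)c1)Nc1ccc2ccccc2c1` gives 240 nM in a functional assay on A549 cells (Homo sapiens) for antiproliferative activity, read by MTT assay, with a stated time of 48 h; a lower number here means a stronger inhibitor, a higher number a weaker inhibitor.
Compound 2 `O=C(NCc1ccccc1)Nc1cccc(NC(=O)c2ccccn2)c1` gives 2990 nM in this assay.
Compound 3 `CN1CCN(C(=S)SCC(=O)Nc2cccc(NC(=O)c3ccccn3)c2)CC1` gives 1340 nM in this assay.

Compound 3 stands second highest of the three numbers in this assay: compound 2 sits at a higher number, beyond the scatter, while compound 1 sits at a lower number, further away. Compound 4 `O=C(CSC(=S)N1CCN(c2ncccn2)CC1)Nc1cccc(NC(=O)c2ccccn2)c1` differs from compound 3 in one place: pyrimidin-2-yl in place of methyl on an amine nitrogen in a ring. For the measured compounds named here, no measured pair shows this change, so compound 3 alone anchors the expectation; the step from compound 3 to compound 4 is expected to be a 1.2-fold lower number from compound 3 to compound 4 (0.09 log units; within the scatter), not beyond the scatter. Compound 4 is therefore estimated at 1100 nM in this assay, within a range from 400 nM to 3000 nM.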

Compound 4, half-maximal inhibitory concentration: 40 nM
Beside the measured number, compound 4's estimate is 28-fold (1.44 log units) above it; measured number outside the range, below it.
By their numbers in this assay, from the lowest: compound 4; then compound 1; then compound 3; then compound 2.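

The amine nitrogen in the ring proves to be a sensitive position: in this assay, pyrimidin-2-yl in place of methyl gives a 34-fold lower number from compound 3 to compound 4 (1.53 log units; beyond the scatter). A single change at this nitrogen, with the rest of the molecule the same, therefore moves the number far beyond the scatter. Nothing at hand accounts for the size of this step.

Going by these compounds, it remains open whether a phenyl or pyridin-2-yl group on this nitrogen would give a step of similar size. Also open, on these data alone, is whether a smaller group, such as ethyl, would already shift the number.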